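The source may report more compounds than this note shows. Statements on the series, on what has been measured and on what is new or still open speak of the compounds shown alone.

Compound 1 `CC(C)[C@@H]1CC[C@@H](C)C[C@@]12N(C)C(=O)[C@@H]1[C@H]3C(=O)N(c4ccccc4)C(=O)[C@H]3ON12`: 900 ug/mL
Compound 2 `COc1ccc(N2C(=O)[C@H]3[C@H](ON4[C@@H]3C(=O)N(C)[C@@]43C[C@H](C)CC[C@H]3C(C)C)C2=O)cc1`: 1120 ug/mL

In a functional assay, with a stated time of 20 min (on this read-out lower numbers stand for stronger inhibition and higher numbers for weaker inhibition), compound 2 gives the highest of the two numbers, with compound 1 within the scatter of it, as shown by a 1.2-fold higher number from compound 1 to compound 2 (0.09 log units; within the scatter). Compound 3 `Cc1cccc(N2C(=O)[C@H]3[C@H](ON4[C@@H]3C(=O)N(C)[C@@]43C[C@H](C)CC[C@H]3C(C)C)C2=O)c1` carries 3-methylphenyl in place of 4-methoxyphenyl on an amide-type nitrogen in a ring. Among the compounds with values here, the only measured step, from compound 1 to compound 2, swapped hydrogen for methoxy on the same ring and stayed within the scatter; no measured step covers a methyl. No change beyond the scatter is therefore expected in this assay, the expected step being a 1.1-fold lower number from compound 2 to compound 3 (0.05 log units; within the scatter). Compound 3 is estimated at 1000 ug/mL, between 500 ug/mL and 2000 ug/mL.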

Compound 3, half-maximal inhibitory concentration: 1880 ug/mL
For compound 3 the middle estimate is 1.9-fold (0.27 log units) below the measured one; the range from low to high includes it.
By their numbers in this assay, from the lowest: compounds 1, 2 and 3 (each within the scatter of the next, the first and the last beyond it).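

At the aryl group on the amide-type nitrogen in a ring, this assay now shows its first step beyond the scatter, though a modest one: the added methyl gives a 2.1-fold higher number from compound 1 to compound 3 (0.32 log units; beyond the scatter) and so weakens inhibition. The change from 4-methoxyphenyl to 3-methylphenyl gives a 1.7-fold higher number from compound 2 to compound 3 (0.22 log units; within the scatter) and does not separate these two compounds. Nothing available explains either step.

A 4-methylphenyl group would show whether the methyl itself or its place on the ring matters. Going by these compounds, how an amine or a carboxylic acid on this ring would read also remains open.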